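The source may report more compounds than this note shows. Statements on the series, on what has been measured and on what is new or still open speak of the compounds shown alone.

Measured compounds in a functional assay on cells for agonist activity at C-X-C chemokine receptor type 4 (Homo sapiens), read by fluorescence and calcium flux, with a stated time of 90 s; a lower number here means that less compound is needed, a higher number that more compound is needed for the effect:

- compound 1 `c1ccc2c(c1)CN[C@@H](CN(CCCCNCC1CCCCC1)[C@H]1CCCc3cccnc31)C2`: > 30000 nM
- compound 2 `c1ccc2c(c1)CN[C@@H](CN(CCCCNCC1CCSCC1)[C@H]1CCCc3cccnc31)C2`: > 30000 nM
- compound 3 `NCc1ccccc1CN(C[C@H]1Cc2ccccc2CN1)[C@H]1CCCc2cccnc21`: > 30000 nM

In this assay compound 1 reaches only the limit of the assay, > 30000 nM. Compound 2 likewise reaches only the limit, > 30000 nM. Compound 3 also gives no number but a limit, > 30000 nM. Compound 3 thus stands where every measured compound of the series stands, at the limit (the limit of > 30000 nM in this assay, at which 3 of the 3 values shown sit); nothing separates it from compound 1 or compound 2.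

The steps toward compound 3, a step that the two limits leave unreadable from compound 1 to compound 3 and a step that the two limits leave unreadable from compound 2 to compound 3, are unreadable, as is a step that the two limits leave unreadable from compound 1 to compound 2. None of them yields a size.

Compound 4 `C(=C/CN(C[C@H]1Cc2ccccc2CN1)[C@H]1CCCc2cccnc21)\CNCc1ccccn1` changes compound 3 as follows: a group of 11 heavy atoms (9 carbon, 2 nitrogen; one six-membered aromatic ring with 1 hetero atom) in place of a group of 8 heavy atoms (7 carbon, 1 nitrogen; one six-membered aromatic ring of carbon only), on a saturated chain carbon bound to an amine nitrogen. Within the data shown here, no measured step bears on this change with a readable size, so the expectation rests on the common outcome of the series. Compound 4 is expected to sit near the limit as well, estimated at 25000 nM, within 3000 nM to 100000 nM. The expected step of an at least 1.2-fold lower number from compound 3 to compound 4 (0.07 log units; that floor lies within the scatter) is therefore essentially nil, with a high chance that only a limit is reported again.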

Compound 4, half-maximal effective concentration: > 30000 nM
Compound 4: only a limit was reported; the forecaster's own chance of this, stated with the estimate: 70%; middle value at least 1.2-fold (0.07 log units) from the limit.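

In this assay compound 4 gives only a limit, > 30000 nM. Among these compounds, no step from compound 1, compound 2 or compound 3 to compound 4 can be read. The compounds shown leave open whether these groups differ at all in half-maximal effective concentration.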